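Compound 1 without one methoxy

This account rests on a few compounds, and the source may have more. Where it says the series, first, only, none or still open, it means among the compounds named here.

Compound 1 `COCCOc1cc2nccc(Oc3ccc(Nc4nccc5[nH]cc(-c6ccc(F)cc6)c(=O)c45)cc3F)c2cc1OC`: 3000 nM
Compound 2 `CC(C)(O)COc1ccc2c(Oc3ccc(Nc4nccc5[nH]cc(-c6ccccc6)c(=O)c45)cc3F)ccnc2c1`: 3600 nM

Within the data shown here, in a functional assay on NCI-H460 cells (Homo sapiens) for antiproliferative activity, read by MTT assay, with a stated time of 72 h (a higher number here means a weaker inhibitor, a lower number a stronger inhibitor), compound 1 and compound 2 lie within the scatter of each other, so compound 1 sits level with the only other measured compound. Compound 3 `COCCOc1ccc2c(Oc3ccc(Nc4nccc5[nH]cc(-c6ccc(F)cc6)c(=O)c45)cc3F)ccnc2c1` carries hydrogen in place of methoxy on an aromatic carbon, ortho to a 2-methoxyethoxy group (hydrogen in place of methoxy on an aromatic carbon). Among the measured compounds shown here, no measured pair shows this change alone, so no step beyond the scatter is expected in this assay. The expected change is a 1.1-fold higher number from compound 1 to compound 3 (0.03 log units; within the scatter). Compound 3 is estimated at 3200 nM, with an expected range of 1300 nM to 8000 nM.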

Compound 3, half-maximal inhibitory concentration: 4300 nM
For compound 3 the middle estimate is 1.3-fold (0.13 log units) below the measured one; low and high end bracket the measured number.
By their numbers in this assay, from the lowest: compounds 1, 2 and 3 (each within the scatter of the next).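

In this assay, among these compounds, this pair gives the first direct reading of the change, a 1.4-fold higher number from compound 1 to compound 3 (0.16 log units; within the scatter) and so hydrogen in place of methoxy on this aromatic carbon, ortho to a 2-methoxyethoxy group, stays within the scatter. The methoxy can therefore be lost here without a step beyond the scatter in these cells. No measurement at hand offers an explanation of this result.

From the compounds shown here alone, whether an amine, a fluorine or a longer alkoxy chain on this same carbon would move the number beyond the scatter stays open.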